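This account rests on a few compounds, and the source may have more. Where it says the series, first, only, none or still open, it means among the compounds named here.

In an assay on CHO cells for displacement of a labelled ligand from histamine receptor H3 (Macaca mulatta), read by scintillation counting, with a stated time of 1 h (on this read-out lower numbers stand for stronger inhibition and higher numbers for weaker inhibition), compound 2 `Cc1cc(N2CC[C@H](N3CCC[C@@H]3C)C2)ccc1NC(=O)c1ccoc1` gives 1.8 nM, the lowest of the two numbers recorded so far. Going by the values given here, its only measured neighbour is compound 1 `Cc1cc(C(=O)Nc2ccc(N3CC[C@H](N4CCC[C@@H]4C)C3)cc2C)n[nH]1`, which in this assay gives 4.7 nM; the two are joined by the step of a 2.6-fold lower number from compound 1 to compound 2 (0.42 log units; beyond the scatter), in which furan-3-yl took the place of 5-methyl-1H-pyrazol-3-yl on the carbonyl carbon. Compound 3 `Cc1cc(N2CC[C@H](N3CCC[C@@H]3C)C2)ccc1NC(=O)c1cc(C)n(C)n1` has not yet been measured in this assay. It differs from compound 2 in one place: 1,5-dimethyl-1H-pyrazol-3-yl in place of furan-3-yl on a carbonyl carbon. Among the compounds with values here, the one measured step that bears on this change is a 2.6-fold lower number from compound 1 to compound 2 (0.42 log units; beyond the scatter), which ran from a pyrazole to the furan and lowered the number modestly; compound 3 runs back from the furan to a pyrazole, now the 1,5-dimethyl variant. The expectation is therefore a modest rise in the number, roughly undoing that earlier step, and the step from compound 2 to compound 3 is expected to come out as a 1.9-fold higher number from compound 2 to compound 3 (0.29 log units; within the scatter). For compound 3 in this assay the estimate is 3.5 nM, within a range of 1.5 nM to 8 nM.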

Compound 3, inhibition constant: 10.8 nM
Estimate against measurement, compound 3: 3.1-fold (0.49 log units) below, outside the stated range (above it).
By their numbers in this assay, from the lowest: compound 2; then compound 1; then compound 3.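

In this assay, the return from the furan to a pyrazole is not a simple undoing of the earlier change: a 6.0-fold higher number from compound 2 to compound 3 (0.78 log units; beyond the scatter) is a larger move than a 2.6-fold lower number from compound 1 to compound 2 (0.42 log units; beyond the scatter), and it leaves compound 3 with the highest number of the three. The new comparison also isolates a change on the pyrazole itself, since the only difference in a 2.3-fold higher number from compound 1 to compound 3 (0.36 log units; beyond the scatter) is methyl in place of hydrogen on an aromatic nitrogen, and that single substitution moves the number beyond the scatter. The group on this carbonyl carbon therefore separates all three compounds, and two pyrazoles that differ by one methyl do not read as equivalent, which compound 1 and compound 2 alone could not show.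

Nothing available here explains why the methyl on the aromatic nitrogen raises the number. As far as these compounds go, it remains open whether an ethyl group on that nitrogen, a pyrazole without the carbon-bound methyl, or a plain phenyl ring on the carbonyl carbon would fit the same order, and whether the order holds on any core other than the shared one.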